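Swapping the Aryl Group in a Weakly Cytotoxic Series

This account rests on a few compounds, and the source may have more. Where it says the series, first, only, none or still open, it means among the compounds named here.

Measured compounds:
compound 1 `C=CCn1c(=O)/c(=C\c2cccc(F)c2)[nH]c(=O)/c1=C\c1ccccc1OC`: 25600 nM
compound 2 `C=CCn1c(=O)/c(=C\c2cccc(Br)c2)[nH]c(=O)/c1=C\c1ccccc1OC`: "not active" (no number reported)
compound 3 `C=CCn1c(=O)/c(=C\c2ccccc2F)[nH]c(=O)/c1=C\c1ccccc1OC`: 25100 nM

In a functional assay on NCI-H1975 cells (Homo sapiens) for cytotoxicity, read by CCK-8 assay, with a stated time of 72 h (on this read-out higher numbers stand for weaker inhibition and lower numbers for stronger inhibition), compound 1 gives 25600 nM. Compound 2 is reported in this assay as "not active" (no number reported), with no number to compare. Compound 3 gives 25100 nM in this assay. Among the compounds with values here, the one step measured between two numbered compounds, a 1.0-fold lower number from compound 1 to compound 3 (0.01 log units; within the scatter), shows that moving the fluorine from one ring position to another changes nothing beyond the scatter, and compound 3 and compound 1 sit together at a weak level; compound 2 adds only that a brominated ring gave no measurable number at all.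

Compound 4 `C=CCn1c(=O)/c(=C\c2ccc(C)cc2)[nH]c(=O)/c1=C\c1ccccc1OC` has not been measured. It differs from compound 3 by 4-methylphenyl in place of 2-fluorophenyl on a double-bonded chain carbon bound to an aromatic carbon. Within the data shown here, no measured step exchanges a halogen for a methyl group on this ring, so the measured pair offers only indirect guidance: one aryl variation left the number essentially unchanged, while another removed activity entirely. The expectation for compound 4 is therefore a step of about a 1.2-fold higher number from compound 3 to compound 4 (0.08 log units; within the scatter) in this assay, that is, no clear movement beyond the scatter, with some chance of no measurable number. Compound 4 is estimated at 30000 nM, within a range of 10000 nM to 100000 nM.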

Compound 4, half-maximal inhibitory concentration: "not active" (no number reported)
Nothing numeric was reported for compound 4, and the estimate cannot be compared.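

In this assay compound 4 is reported as "not active" with no number, so no step from compound 3 to compound 4 can be read, and nothing measured here accounts for this result. The compounds shown leave open how far compound 2 and compound 4 lie from compound 1 and compound 3.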